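The source may report more compounds than this note shows. Statements on the series, on what has been measured and on what is new or still open speak of the compounds shown alone.

Measured in a functional assay on BGC-823 cells (Homo sapiens) for antiproliferative activity, read by MTT assay, with a stated time of 48 h; a lower number here means a stronger inhibitor, a higher number a weaker inhibitor:
- compound 1 `Cc1ccc(N2CCN(Cn3nc(-c4ccc5c(c4)OCCO5)oc3=S)CC2)c(C)c1` gives 28300 nM as a number
- compound 2 `S=c1oc(-c2ccc3c(c2)OCCO3)nn1CN1CCN(c2cccc(Cl)c2)CC1` gives > 50000 nM as a limit
- compound 3 `Fc1ccc(N2CCN(Cn3nc(-c4ccc5c(c4)OCCO5)oc3=S)CC2)cc1` gives > 50000 nM as a limit

Compound 2 stands at the limit of > 50000 nM in this assay, at which 2 of the 3 values shown sit, and so has no number of its own. Compound 4 `S=c1oc(-c2ccc3c(c2)OCCO3)nn1CN1CCN(c2ccccc2Cl)CC1` is not yet measured. Its difference from compound 2 is 2-chlorophenyl in place of 3-chlorophenyl on an amine nitrogen in a ring and amounts to 2-chlorophenyl in place of 3-chlorophenyl on an amine nitrogen in a ring.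

The bearing steps are those at the same place. These are an at least 1.7-fold higher number from compound 1 to compound 2 (0.24 log units; that floor lies within the scatter) and an at least 1.7-fold higher number from compound 1 to compound 3 (0.24 log units; that floor lies within the scatter) as floors only. The remaining one, a step that the two limits leave unreadable from compound 2 to compound 3 gives no size. None of the three shows a change beyond the scatter, so no step beyond the scatter is expected in this assay and no direction can be read. Compound 1 at 28300 nM sets the expected lower end of the range. A further limit is the likeliest report.

For compound 4 the estimated value is 45000 nM with an expected range from 20000 nM to 70000 nM in these notes. The expected move is an at least 1.1-fold lower number from compound 2 to compound 4 (0.04 log units; that floor lies within the scatter) and remains an estimate.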

Compound 4, half-maximal inhibitory concentration: > 50000 nM
Compound 4: a limit, no number (the forecaster's own chance of this, stated with the estimate: 65%); middle value at least 1.1-fold (0.04 log units) from the limit.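

In this assay compound 4 also gives a limit and not a number, so 2-chlorophenyl on this amine nitrogen, like 3-chlorophenyl and 4-fluorophenyl, yields no measurable value: the limit of > 50000 nM in this assay, at which 3 of the 4 values shown sit.

The steps among compounds 2, 3 and 4 cannot be read, so the two chlorophenyl isomers cannot be ordered. The only readable step is a floor, an at least 1.7-fold higher number from compound 1 to compound 4 (0.24 log units; that floor lies within the scatter), so although compound 1 alone has a number, 2,4-dimethylphenyl is not shown to differ from 2-chlorophenyl.

Going by these compounds, it remains open whether any change on this phenyl gives a step beyond the scatter. A methoxy group or a carboxylic acid in place of the chlorine would test whether a number can be obtained here at all.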